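The compounds below may be only part of what the source reports. "The series", "measured", "known", "first", "only" and "open" are said of these compounds alone.

Compound 1, `Cc1cccc(-n2nncc2CN2C(=O)C3(C(C#N)=C(N)Oc4c(N)cc5nc6ccccc6nc5c43)c3ccccc32)c1`: > 50000 nM
Compound 2, `N#CC1=C(N)Oc2c(N)cc3nc4ccccc4nc3c2C12C(=O)N(Cc1cnnn1-c1ccc(F)c(Cl)c1)c1ccccc12`: > 50000 nM

Both compounds were tested in a functional assay on HepG2 cells (Homo sapiens) for antiproliferative activity, read by MTT assay, with a stated time of 48 h; on this read-out lower numbers stand for stronger inhibition and higher numbers for weaker inhibition. For compound 1 the value > 50000 nM is a limit of the assay rather than a number. For compound 2 the value > 50000 nM is likewise a limit, not a number. The step that the two limits leave unreadable from compound 1 to compound 2 therefore cannot be read, as shown by the limit of > 50000 nM in this assay, at which 2 of the 2 values shown sit. Compound 2 thus stands at the limit of this assay, with no number to place it against compound 1.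

Compound 3, `N#CC1=C(N)Oc2c(N)cc3nc4ccccc4nc3c2C12C(=O)N(Cc1cnnn1-c1ccc([N+](=O)[O-])cc1[N+](=O)[O-])c1ccccc12`, has not yet been measured in this assay. It differs from compound 2 in one place: 2,4-dinitrophenyl in place of 3-chloro-4-fluorophenyl on an aromatic nitrogen. Going by the values given here, the only measured step that touches this position is the one from compound 1 to compound 2, a step that the two limits leave unreadable from compound 1 to compound 2, and its size is not readable, both its ends being limits. Among the compounds with values here, no measured step gives a direction for this change in this assay. Compound 3 is therefore expected to remain at or near the limit, with an expected step that the limit leaves unreadable from compound 2 to compound 3 that does not exceed the scatter. The estimate for compound 3 is 60000 nM, with a range from 20000 nM to 200000 nM.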

Compound 3, half-maximal inhibitory concentration: 18400 nM
Beside the measured number, compound 3's estimate is 3.3-fold (0.51 log units) above it; the measured number lies below the stated range.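

Putting 2,4-dinitrophenyl in place of 3-chloro-4-fluorophenyl on the aromatic nitrogen gives an at least 2.7-fold lower number from compound 2 to compound 3 (0.43 log units; beyond the scatter) in this assay, and putting it in place of 3-methylphenyl gives an at least 2.7-fold lower number from compound 1 to compound 3 (0.43 log units; beyond the scatter). The earlier pair gave no readable step at this position, whereas these two show that a change of this group can register on the read-out, and that for 2,4-dinitrophenyl the direction is towards stronger inhibition, though the inhibition of compound 3 remains in the micromolar range. Both sizes are only lower bounds, and the step between compound 1 and compound 2 still cannot be read, because those two compounds stand at a limit and not at a number: the limit of > 50000 nM in this assay, at which 2 of the 3 values shown sit.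

The compounds shown leave open whether a phenyl carrying a single nitro group would give a similar lower number, or whether the step needs both nitro groups. They also leave open how an amine or a carboxylic acid on this phenyl ring would read in this assay, and whether any group at this position can lower the number further than compound 3 does.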